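A few compounds are considered here, and "the series" means these few. Any claim that something is new, unique, unknown or untested is made for them only; others in the source may bear on it.

Measured in a functional assay on PC-3 cells (Homo sapiens) for inhibition, read by sulforhodamine B assay, with a stated time of 72 h; a higher number here means a weaker inhibitor, a lower number a stronger inhibitor:
- compound 1 `CCOC(=O)Nc1sc(-c2ccc(Cl)cc2)c(-c2ccc(Cl)cc2)c1C(=O)NC1CC1`: 27600 nM
- compound 2 `CN1CCN(C(=O)c2c(N)sc(-c3ccc(Cl)cc3)c2-c2ccc(Cl)cc2)CC1`: 13100 nM
- compound 3 `Nc1sc(-c2ccc(Cl)cc2)c(-c2ccc(Cl)cc2)c1C(=O)NCc1ccccc1`: 31800 nM

Compound 3 lies within the scatter of compound 1, and its number is higher than that of compound 2. Compound 4 `Nc1sc(-c2ccc(Cl)cc2)c(-c2ccc(Cl)cc2)c1C(=O)NC1CC1` has cyclopropyl in place of benzyl on an amide-type nitrogen. Among the compounds with values here, only one measured step changes this part of the molecule, a 2.4-fold higher number from compound 2 to compound 3 (0.39 log units; beyond the scatter), and it is modest. Within the data shown here, no measured step makes this exact swap. Compound 1, which also has cyclopropyl on that nitrogen, gives 27600 nM. So no step beyond the scatter is expected in this assay, and the direction stays open. The estimated step is a 1.3-fold lower number from compound 3 to compound 4 (0.12 log units; within the scatter). For compound 4 the expected value is 24000 nM, with an estimated range of 10000 nM to 55000 nM.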

Compound 4, half-maximal inhibitory concentration: 3680 nM
The estimate for compound 4 lay 6.5-fold (0.81 log units) above the measured number; the whole stated range lies above it.
By their numbers in this assay, from the lowest: compound 4; then compound 2; then compounds 1 and 3 (each within the scatter of the next).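

Cyclopropyl in place of benzyl on the amide-type nitrogen gives an 8.6-fold lower number from compound 3 to compound 4 (0.94 log units; beyond the scatter) in this assay, and cyclopropylamino in place of 4-methylpiperazin-1-yl on the carbonyl carbon gives a 3.6-fold lower number from compound 2 to compound 4 (0.55 log units; beyond the scatter), so this position can shift the number more than the earlier step showed. Cyclopropyl does not act alone, as hydrogen in place of ethoxycarbonyl on the nitrogen on the aromatic ring gives a 7.5-fold lower number from compound 1 to compound 4 (0.88 log units; beyond the scatter). Nothing measured here explains these steps. Going by these compounds, whether cyclobutyl or an ethyl chain on the amide-type nitrogen would give a similar number remains open.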